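Amide-side variation on the shared core: cytotoxicity notes

The source may hold more compounds than are shown below. What is called first, only, known or untested is meant among the compounds shown, and "the series" means these compounds.

Compound 1 `CCCOCC(=O)Nc1cc2nc(C3CCCCC3)[nH]c2cc1N(CC)CC` carries propoxymethyl on the carbonyl carbon. In an ADME assay on Vero cells (Chlorocebus sabaeus) for cytotoxicity, read by resazurin assay, with a stated time of 3 days (on this read-out lower numbers stand for stronger inhibition and higher numbers for weaker inhibition), compound 1 gives > 100 ug/mL, a limit of the assay rather than a number. Compound 2 `CCc1ccc(C(=O)Nc2cc3nc(C4CCCCC4)[nH]c3cc2N(CC)CC)cc1` has 4-ethylphenyl in place of propoxymethyl on that carbonyl carbon. In this assay compound 2 gives > 100 ug/mL, again a limit. The step that the two limits leave unreadable from compound 1 to compound 2 is unreadable because both values sit at the limit of > 100 ug/mL in this assay, at which 2 of the 2 values shown sit. Compound 3 `CCN(CC)c1cc2[nH]c(C3CCCCC3)nc2cc1NC(=O)OCCOCCOC` differs from compound 2 by 2-(2-methoxyethoxy)ethoxy in place of 4-ethylphenyl on a carbonyl carbon. Going by the values given here, no measured step bears on this change. The step of a number no higher from compound 2 to compound 3 (the limit leaves the size open) is expected to stay within the scatter. Compound 3 is estimated at 100 ug/mL, between 50 ug/mL and 200 ug/mL, most likely reported once more as a limit.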

Compound 3, half-maximal inhibitory concentration: > 100 ug/mL
Compound 3 ended at the assay's limit (the forecaster's own chance of this, stated with the estimate: 85%); the middle value sits exactly at the limit.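

No step can be read among compound 1, compound 2 and compound 3, as each value is a limit and not a number: the limit of > 100 ug/mL in this assay, at which 3 of the 3 values shown sit.

The compounds shown leave open how far any amide-side group on the shared core moves cytotoxicity.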